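Four hydrazine compounds at the dosing limit in mice

A few compounds are considered here, and "the series" means these few. Any claim that something is new, unique, unknown or untested is made for them only; others in the source may bear on it.

Compound 1 `Cc1ccccc1-c1nnc(NNC2CCCC2)s1`, compound 2 `Cc1ccccc1-c1nnc(NNc2ccccc2)s1` and compound 3 `Clc1ccccc1-c1nnc(NNC2CCCC2)s1` share one core and were tested in a functional assay on the whole organism with Mus musculus as the target, with a stated time of 1 h; on this read-out higher numbers stand for an effect only at larger amounts of compound and lower numbers for an effect already at smaller amounts. Compound 1 gives > 100 mg/kg, which is a limit of the assay rather than a number. Compound 2 gives > 100 mg/kg, also a limit. Compound 3 gives > 100 mg/kg, once more a limit. Compound 2 differs from compound 1 by phenyl in place of cyclopentyl on an amine nitrogen, and the result is a step that the two limits leave unreadable from compound 1 to compound 2. Compound 3 differs from compound 1 by chloro in place of methyl on an aromatic carbon, giving a step that the two limits leave unreadable from compound 1 to compound 3. All three values sit at the limit of > 100 mg/kg in this assay, at which 3 of the 3 values shown sit. Compound 4 `Clc1ccccc1-c1nnc(NNc2ccccc2)s1` is not yet measured; it differs from compound 3 by phenyl in place of cyclopentyl on an amine nitrogen, the same change as from compound 1 to compound 2. Because all measured values sit at the limit of > 100 mg/kg in this assay, at which 3 of the 3 values shown sit, compound 4 is expected to show a step that the limit leaves unreadable from compound 3 to compound 4 in this assay. The estimate for compound 4 is 150 mg/kg, between 70 mg/kg and 400 mg/kg, most likely reported only as a limit.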

Compound 4, dose for half-maximal effect: > 200 mg/kg
Compound 4: only a limit was reported; the forecaster's own chance of this, stated with the estimate: 85%; middle value at least 1.3-fold (0.12 log units) from the limit.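

Compound 4 gives > 200 mg/kg as a limit, so the steps to it from compound 2 and compound 3 cannot be read. The compounds shown leave open what dose of any of them gives a half-maximal effect.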